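The compounds below may be only part of what the source reports. "The series", "measured", "known", "first", "only" and "open" are said of these compounds alone.

Measured in a functional assay on HL-60 cells (Homo sapiens) for inhibition, with a stated time of 72 h; on this read-out lower numbers stand for stronger inhibition and higher numbers for weaker inhibition:
- compound 1 `[N-]=[N+]=NCc1ncnc2c1ncn2[C@@H]1O[C@H](CO)[C@@H](O)[C@H]1O`: 1880 nM
- compound 2 `CN(Cc1ncnc2c1ncn2[C@@H]1O[C@H](CO)[C@@H](O)[C@H]1O)c1ccccc1`: 4000 nM

Of these two numbers, compound 2 has the higher, which makes it the weaker inhibitor of the pair. Its gap to compound 1 lies beyond the usual scatter.

The next compound, compound 3 `CSCc1ncnc2c1ncn2[C@@H]1O[C@H](CO)[C@@H](O)[C@H]1O`, keeps the shared core and changes one group: methylsulfanyl in place of methyl(phenyl)amino on a saturated chain carbon bound to an aromatic carbon.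

Among the compounds with values here, only one measured step bears on this change: a 2.1-fold higher number from compound 1 to compound 2 (0.33 log units; beyond the scatter). It is modest, and it came when methyl(phenyl)amino replaced azido on the same kind of carbon. So the group that carries a ring went with the higher number, although two compounds cannot establish a trend, and methylsulfanyl itself has not been measured. With that ring gone, a modest move towards a lower number in this assay is expected, of about the same size as the measured step. The expected change is a 1.8-fold lower number from compound 2 to compound 3 (0.26 log units; within the scatter). For compound 3 the estimate is 2200 nM, with an expected range of 700 nM to 6000 nM.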

Compound 3, half-maximal inhibitory concentration: 13400 nM
Compound 3: the middle estimate sits 6.1-fold (0.78 log units) below what was measured; measured number above the stated range.
By their numbers in this assay, from the lowest: compound 1; then compound 2; then compound 3.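

On this assay, the swap of methyl(phenyl)amino for methylsulfanyl gives a 3.4-fold higher number from compound 2 to compound 3 (0.53 log units; beyond the scatter), so losing the aromatic ring does not by itself bring the number down at this position. Set against azido, the same group gives a 7.1-fold higher number from compound 1 to compound 3 (0.85 log units; beyond the scatter), which places the three groups on this saturated chain carbon in the order azido, methyl(phenyl)amino, methylsulfanyl, from the lowest number to the highest, and the two groups without a ring sit at opposite ends of that order. The presence of an aromatic ring therefore does not sort these three compounds, and no measurement at hand explains the order.

The compounds shown leave open whether the sulfur atom goes with the high number of compound 3, a question that a methoxy group or a dimethylamino group on the same kind of carbon could help to answer. They also leave open how the number responds to a longer chain on the sulfur, such as ethylsulfanyl, or to a phenylsulfanyl group, which would put the aromatic ring back while keeping the sulfur.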